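Swapping a Chloro-Aryl Ring for a Nitrobenzyl Group

This account rests on a few compounds, and the source may have more. Where it says the series, first, only, none or still open, it means among the compounds named here.

Compound 1 `Cc1cc(Cl)cc(-c2c(C)nn(-c3nc(-c4ccc(Cl)c(Cl)c4)c(SC(C)C)s3)c2C(=O)O)c1`: 663 nM
Compound 2 `Cc1nn(-c2nc(-c3ccc(Cl)c(Cl)c3)c(SC(C)C)s2)c(C(=O)O)c1-c1cncc(C#N)c1`: 20000 nM
Compound 3 `Cc1nn(-c2nc(-c3ccc(Cl)c(Cl)c3)c(SC(C)C)s2)c(C(=O)O)c1-c1ccccc1Cl`: 13100 nM

In a functional assay on BJAB cells (Homo sapiens) for antiproliferative activity, with a stated time of 4 days (on this read-out higher numbers stand for an effect only at larger amounts of compound and lower numbers for an effect already at smaller amounts), compound 3 stands second highest of the three numbers. Its nearest neighbour is compound 2, with a 1.5-fold lower number from compound 2 to compound 3 (0.18 log units; within the scatter), while compound 1 lies far off, shown by a 20-fold higher number from compound 1 to compound 3 (1.30 log units; beyond the scatter). Compound 4 `Cc1nn(-c2nc(-c3ccc(Cl)c(Cl)c3)c(SC(C)C)s2)c(C(=O)O)c1Cc1ccccc1[N+](=O)[O-]` differs from compound 3 by 2-nitrobenzyl in place of 2-chlorophenyl on an aromatic carbon. Within the data shown here, no measured step tests this exact exchange. The two measured steps at this position, a 30-fold higher number from compound 1 to compound 2 (1.48 log units; beyond the scatter) and a 20-fold higher number from compound 1 to compound 3 (1.30 log units; beyond the scatter), were both large, so the spot clearly matters, but both replaced one aromatic ring with another and neither introduced a benzyl group. Compound 4 is therefore estimated at 13000 nM, within 3000 nM to 40000 nM, and the expected step of a 1.0-fold lower number from compound 3 to compound 4 (0.00 log units; within the scatter) is not beyond the scatter.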

Compound 4, half-maximal effective concentration: 20000 nM
Estimate against measurement, compound 4: 1.5-fold (0.19 log units) below; the measured number falls inside the stated range.
By their numbers in this assay, from the lowest: compound 1; then compounds 3, 2 and 4 (each within the scatter of the next).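

In (this assay), the 2-nitrobenzyl group, unlike the earlier ring groups, is a benzyl group, yet it gives (a 1.5-fold higher number from compound 3 to compound 4 (0.18 log units; within the scatter)) and (no change at the digits printed from compound 2 to compound 4 (within the scatter)), so it joins the 2-chlorophenyl and 5-cyanopyridin-3-yl compounds within the scatter. Set against the 3-chloro-5-methylphenyl group, it gives (a 30-fold higher number from compound 1 to compound 4 (1.48 log units; beyond the scatter)), which leaves compound 1 alone in acting at smaller amounts among these four. Nothing available explains this pattern. Going by these compounds, whether a benzyl group carrying chlorine and methyl would match compound 1 remains open. So does the outcome with an amine or a longer carbon chain here.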